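A few compounds are considered here, and "the series" means these few. Any claim that something is new, unique, unknown or untested is made for them only; others in the source may bear on it.

Measured in a functional assay on CHO cells for agonist activity at Free fatty acid receptor 2 (Homo sapiens), read by cAMP accumulation; on this read-out higher numbers stand for weaker inhibition and lower numbers for stronger inhibition:

Compound 1 `CC(C)[C@H](C(=O)Nc1ccc(F)cn1)c1ccc(Cl)cc1`: 1300 nM
Compound 3 `CC(C)C(C(=O)Nc1nc2ccccc2s1)c1ccc(Cl)cc1`: 3000 nM
Compound 2 `CC(C)C(C(=O)Nc1nnn[nH]1)c1ccc(Cl)cc1`: 100000 nM

Three amides built on a shared core have been measured in this assay. Compound 1 gives the lowest number of the three. Compound 3, which carries a bicyclic heteroaryl on the amide nitrogen, returns a number that lies beyond the scatter above that of compound 1, and compound 2, with a tetrazolyl on the same nitrogen, sits far weaker still. Within these three, then, the identity of the group on the amide nitrogen decides the whole spread.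

Compound 4 `Cc1csc(NC(=O)[C@H](c2ccc(Cl)cc2)C(C)C)n1` is the next member, not yet measured. It differs from compound 1 by 4-methyl-1,3-thiazol-2-yl in place of 5-fluoropyridin-2-yl on an amide-type nitrogen. Within the data shown here, no measured pair shows this exact exchange, so the size of the step can only be judged from what the three measured compounds show: small aromatic groups on the amide nitrogen give the lower numbers, the tetrazolyl the highest.

Compound 4 is therefore expected to land close to compound 1, with the step from compound 1 to compound 4 estimated at a 1.6-fold lower number from compound 1 to compound 4 (0.21 log units; within the scatter), a change that would not clearly exceed the scatter. The estimate for compound 4 in this assay is 800 nM, with a range from 250 nM to 2500 nM.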

Compound 4, half-maximal inhibitory concentration: 1400 nM
Compound 4: middle estimate off by 1.8-fold (0.24 log units), on the low side; the range from low to high includes it.
By their numbers in this assay, from the lowest: compounds 1 and 4 (each within the scatter of the next); then compound 3; then compound 2.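

In this assay, among these compounds, 4-methyl-1,3-thiazol-2-yl in place of 5-fluoropyridin-2-yl on the amide-type nitrogen gives a 1.1-fold higher number from compound 1 to compound 4 (0.03 log units; within the scatter), the first step between compounds that differ in one place. The earlier compounds had shown only how widely the numbers can spread with the group on this nitrogen; this pair shows that a one five-membered aromatic ring with 2 hetero atoms and a one six-membered aromatic ring with 1 hetero atom can stand there without a difference that this read-out can separate from the scatter. Nothing measured here explains why these two groups read alike.

The compounds shown leave open whether the methyl of the 4-methyl-1,3-thiazol-2-yl group or the fluorine of the 5-fluoropyridin-2-yl group contributes anything, as neither ring appears here without its substituent. They also leave open what a simple unsubstituted phenyl ring, a longer alkyl chain or a carboxylic acid on the amide nitrogen would give in the place of these two aromatic groups.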